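Adding a hydroxy to the chain of compound 3

The compounds below may be only part of what the source reports. "The series", "measured", "known", "first", "only" and "open" are said of these compounds alone.

In a functional assay on ileum (Cavia porcellus) for antagonist activity (a lower number here means a stronger inhibitor, a higher number a weaker inhibitor), compound 1 `N#Cc1ccc(OCCCOc2ccc3c(O)c([N+](=O)[O-])c(=O)oc3c2)cc1` gives > 10000 nM, which is a limit of the assay and not a number. Compound 2 `Cc1cccc(OCCCOc2ccc3c(O)c([N+](=O)[O-])c(=O)oc3c2)c1` gives 4400 nM and compound 3 `CC(=O)c1ccc(OCCCOc2ccc3c(O)c([N+](=O)[O-])c(=O)oc3c2)cc1O` gives 2800 nM, two values within the scatter of each other. Compound 4 `CC(=O)c1ccc(OCC(O)COc2ccc3c(O)c([N+](=O)[O-])c(=O)oc3c2)cc1O` differs from compound 3 by hydroxy in place of hydrogen on a saturated chain carbon bound to two saturated chain carbons.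

Every measured step exchanges the substituted phenyl group and leaves the chain untouched. They are an at least 2.2-fold lower number from compound 1 to compound 2 (0.35 log units; beyond the scatter), an at least 3.5-fold lower number from compound 1 to compound 3 (0.55 log units; beyond the scatter) and a 1.6-fold lower number from compound 2 to compound 3 (0.20 log units; within the scatter). None of them therefore tests this change directly, and the data give no sign of its direction. The expectation stays anchored on compound 3 at 2800 nM, with no step beyond the scatter in this assay. The estimated step is a 1.1-fold lower number from compound 3 to compound 4 (0.05 log units; within the scatter). For compound 4 the expected value is 2500 nM, with an estimated range of 700 nM to 9000 nM.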

Compound 4, half-maximal inhibitory concentration: > 20000 nM
Compound 4: a limit, no number; the forecaster's own chance of this, stated with the estimate: 12%; middle value at least 8.0-fold (0.90 log units) from the limit.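

Among these compounds, the chain is changed here for the first time, and the change matters: in this assay, there is an at least 7.1-fold higher number from compound 3 to compound 4 (0.85 log units; beyond the scatter). A single hydroxy in place of hydrogen on a saturated chain carbon bound to two saturated chain carbons therefore weakens inhibition beyond the scatter, something the earlier exchanges of the phenyl group could not show. The reading for compound 4 is a limit of the assay and not a number: the limit of > 20000 nM in this assay, at which 1 of the 4 values shown sits.

Going by these compounds, it remains open whether the loss belongs to the hydroxy itself or would follow any group on this chain carbon, such as a methoxy or an amine, and whether a longer chain would behave differently. Also open, on these data alone, is whether the same hydroxy would have a similar effect with the 3-methylphenyl group of compound 2 in place of 4-acetyl-3-hydroxyphenyl.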